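This account rests on a few compounds, and the source may have more. Where it says the series, first, only, none or still open, it means among the compounds named here.

Three compounds have been run in a functional assay on cells for agonist activity at Glucose-dependent insulinotropic receptor (Homo sapiens), read by a luciferase reporter, with a stated time of 4 h; on this read-out lower numbers stand for smaller maximal responses and higher numbers for larger maximal responses. Compound 1 `CC(C)(C)OC(=O)N1CCC(c2coc3c(Nc4ccc(S(C)(=O)=O)cc4F)ncnc23)CC1` gives 123% in this assay. Compound 2 `CC(O)c1cnc(N2CCC(c3coc4c(N5CCc6cc(S(C)(=O)=O)ccc65)ncnc34)CC2)nc1` gives 33% in this assay, and compound 3 `CC(C)(C)OC(=O)N1CCC(c2c[nH]c3c(Nc4ccc(S(C)(=O)=O)cc4F)ncnc23)CC1` gives 9% in this assay. Among these three numbers compound 2 stands second highest: compound 3 lies below it by a gap beyond the usual scatter, and compound 1 lies far above it, also beyond the scatter. None of these three pairs differs in a single place, so nothing beyond the values themselves can be said of what separates them.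

Compound 4 `COc1cnc(N2CCC(c3coc4c(N5CCc6cc(S(C)(=O)=O)ccc65)ncnc34)CC2)nc1` differs from compound 2 in one place: methoxy in place of 1-hydroxyethyl on an aromatic carbon. The remainder of the structure is unchanged.

Because compound 2 gives 33% in this assay and the replacement is small, the expectation is that compound 4 stays near compound 2, with the step of a number 2 percentage points higher from compound 2 to compound 4 (within the scatter) expected to fall within the scatter rather than beyond it in either direction. Compound 4 is therefore estimated to give 35% in this assay, with a range from 15% to 60%.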

Compound 4, largest response reached (Emax), in percent of the reference or control that the assay uses: 186%
Compound 4: the middle estimate sits 151 percentage points below what was measured; measured number above the stated range.
By their numbers in this assay, from the lowest: compound 3; then compound 2; then compound 1; then compound 4.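

In this assay, the step of a number 153 percentage points higher from compound 2 to compound 4 (beyond the scatter) shows that the maximal response is highly sensitive to the group at this position, on an aromatic carbon para to a large group, even though the rest of the structure is unchanged. Going by these compounds alone, this is the first pair that differs in one place, and it ties a large gain in maximal response to the change from 5-(1-hydroxyethyl)pyrimidin-2-yl to 5-methoxypyrimidin-2-yl, in which the entering methoxy has fewer heavy atoms and no hydrogen-bond donor. No measurement at hand accounts for the size of this step, so the pair records the effect of the change without explaining it.

The compounds shown leave open which difference between the two groups matters, since the loss of the hydrogen-bond donor, the smaller size and the different attachment atom all arrive together in this single step. They also leave open how the response would run with a hydroxymethyl, an ethoxy, a methyl or an amine at this position, and whether the same change would have a similar effect on another core.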